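A few compounds are considered here, and "the series" means these few. Any claim that something is new, unique, unknown or untested is made for them only; others in the source may bear on it.

Measured compounds:
compound 1, `NC1CCC(Nc2nc(NCc3ccc(-c4ccsc4)cc3)c3ncn(C4CCCC4)c3n2)CC1`, with 315 nM in a functional assay on HCT-116 cells (Homo sapiens) for inhibition, with a stated time of 72 h; on this read-out higher numbers stand for weaker inhibition and lower numbers for stronger inhibition
compound 2, `NC1CCC(Nc2nc(NCc3ccc(-c4ccccc4O)cc3)c3ncn(C4CCCC4)c3n2)CC1`, with 4350 nM

Compound 1 stands at the lowest of the two numbers; the nearest is compound 2, reached by a 14-fold higher number from compound 1 to compound 2 (1.14 log units; beyond the scatter). Compound 3, `NC1CCC(Nc2nc(NCc3cc(Cl)ccc3O)c3ncn(C4CCCC4)c3n2)CC1`, is not yet measured; it differs from compound 1 by 5-chloro-2-hydroxyphenyl in place of 4-(thiophen-3-yl)phenyl on a saturated chain carbon bound to a nitrogen on an aromatic ring. Within the data shown here, the only measured step that bears on it is the one from compound 1 to compound 2, which is large and moved toward weaker inhibition while introducing a hydroxy-bearing phenyl in the same region. The step for compound 3 is therefore expected to run in the same direction, as a 7.9-fold higher number from compound 1 to compound 3 (0.90 log units; beyond the scatter). Compound 3 is estimated at 2500 nM, with a range of 600 nM to 10000 nM.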

Compound 3, half-maximal inhibitory concentration: 350 nM
Estimate against measurement, compound 3: 7.1-fold (0.85 log units) above; the whole stated range lies above it.
By their numbers in this assay, from the lowest: compounds 1 and 3 (each within the scatter of the next); then compound 2.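

In this assay, the smaller 5-chloro-2-hydroxyphenyl takes the place of 4-(thiophen-3-yl)phenyl on the saturated chain carbon with a 1.1-fold higher number from compound 1 to compound 3 (0.05 log units; within the scatter), so the thiophene ring is not needed at this position to keep the number. A hydroxy group on the entering ring therefore does not by itself bring a large step like a 14-fold higher number from compound 1 to compound 2 (1.14 log units; beyond the scatter). Nothing available explains this result. The compounds shown leave open what the chlorine and the hydroxy each contribute, since neither appears alone on this ring. They also leave open whether an amine in place of the hydroxy would give a similar number.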